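Replacing a Two-Ring Amide Substituent with a Fluorinated Sulfone Ring

The compounds below may be only part of what the source reports. "The series", "measured", "known", "first", "only" and "open" are said of these compounds alone.

Compound 1 `O=C(O)C12CCC(C(=O)N3CC[C@](c4ccc(C(F)(C(F)(F)F)C(F)(F)F)cc4)(S(=O)(=O)c4ccc(F)cc4)C3)(CC1)OC2` is the reference point here. For the measured compounds named here, in an ADME assay on microsomes from liver (Mus musculus) for metabolic stability, with a stated time of 10 min (on this read-out lower numbers stand for a less stable compound and higher numbers for a more stable compound), compound 1 gives 94%, the only single number in the set; compound 2 `O=C1NC(=O)C2(CCC(C(=O)N3CC[C@](c4ccc(C(F)(C(F)(F)F)C(F)(F)F)cc4)(S(=O)(=O)c4ccc(F)cc4)C3)CC2)N1` appears through several entries, giving 81%; 82% (2 entries) in this assay (the several entries of compound 2 in this assay, 81%; 82% (2 entries)), and these values lie under those of compound 1. Compound 3 `O=C(N1CC[C@](c2ccc(C(F)(C(F)(F)F)C(F)(F)F)cc2)(S(=O)(=O)c2ccc(F)cc2)C1)C1(F)CCS(=O)(=O)CC1` has not yet been measured. It differs from compound 1 in one place (a group of 9 heavy atoms (5 carbon, 2 oxygen, 1 fluorine, 1 sulfur; one six-membered non-aromatic ring with 1 hetero atom) in place of a group of 11 heavy atoms (8 carbon, 3 oxygen; one six-membered non-aromatic ring of carbon only, one six-membered non-aromatic ring with 1 hetero atom), on a carbonyl carbon), the 4-fluoro-1,1-dioxothian-4-yl group taking the position on the carbonyl carbon whose other neighbour is an amide-type nitrogen in a ring. Going by the values given here, no measured pair shows how this kind of change acts in this assay, so the direction rests on the two measured compounds alone, both of which sit high. A moderate fall beyond the scatter is expected rather than a large one. Compound 3 is estimated at 72%, within 45% to 92%, an expected step of a number 22 percentage points lower from compound 1 to compound 3 (beyond the scatter).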

Compound 3, percent of the compound remaining: 90%
Estimate against measurement, compound 3: 18 percentage points below, within the range that was stated.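

In this assay, for the compounds shown here, putting 4-fluoro-1,1-dioxothian-4-yl on the carbonyl carbon in place of the two-ring group gives a number 4 percentage points lower from compound 1 to compound 3 (within the scatter), the first reading of a single change at this position. In this pair, the high number therefore does not need the carbon-only ring or the hydrogen-bond donor of the leaving group, and the smaller entering group, with its sulfur and fluorine, keeps the number within the scatter. Compound 2, which has no listed step to either compound, also stands high in this read-out: the several entries of compound 2 in this assay, 81%; 82% (2 entries)

What the compounds shown leave open is whether the fluorine of the entering group contributes anything, since the same sulfone ring carrying hydrogen in its place is absent from this set. They also leave open whether an amine or a longer chain on this carbonyl carbon would hold the number as well.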